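Two Compounds Tolerated to the Limit, a Third Expected

This account rests on a few compounds, and the source may have more. Where it says the series, first, only, none or still open, it means among the compounds named here.

Measured so far:
compound 1, `CCC(=O)Nc1ccc(-c2nc3cc(C(F)(F)F)ccc3[nH]2)cc1`, reaches the limit > 100000 nM
compound 2, `CC(=O)Nc1ccc(-c2nc3ccccc3[nH]2)cc1`, reaches the limit > 100000 nM

In an ADME assay on MDBK cells (Bos taurus) for cytotoxicity, read by MTT assay, with a stated time of 96 h (a lower number here means that less compound is tolerated, a higher number that more compound is tolerated), compound 1 gives > 100000 nM, which is a limit of the measurement and not a number. Compound 2 stands at the same place in this assay, with > 100000 nM, again a limit rather than a number. For the measured compounds named here, both values shown therefore sit at the limit of > 100000 nM in this assay, at which 2 of the 2 values shown sit, and no step between two measured compounds can be drawn from them, so nothing here says how any change in structure moves the read-out.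

Compound 3, `CCC(=O)Nc1ccc(-c2nc3ccccc3[nH]2)cc1`, has not been measured. It differs from compound 2 by methyl in place of hydrogen on a saturated chain carbon bound to a carbonyl carbon. The same change, seen one bond further out, reads acetamido to propanoylamino. Since compound 2 reached only the limit > 100000 nM, a step of no size beyond the scatter is expected in this assay for this change, in neither direction. Compound 3 is therefore expected to give 150000 nM, within a range from 60000 nM to 400000 nM. The estimated step is a step that the limit leaves unreadable from compound 2 to compound 3, and compound 3 is expected most likely to reach the limit as well.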

Compound 3, half-maximal cytotoxic concentration: > 100000 nM
Compound 3: no number, only a limit; the forecaster's own chance of this, stated with the estimate: 85%; the middle value is on the limit's open side.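

In this assay compound 3 gives > 100000 nM, which is a limit and not a number. For the compounds shown here, no step from compound 1 or compound 2 to compound 3 can be read, since all three stand at the same place: the limit of > 100000 nM in this assay, at which 3 of the 3 values shown sit. The compounds shown leave open which change in structure, if any, would give a readable number in this assay.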